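The source may report more compounds than this note shows. Statements on the series, on what has been measured and on what is new or still open speak of the compounds shown alone.

Measured compounds:
compound 1 `N=C(N)NCCC[C@H](NC(=O)CN(c1nc(Cl)nc2[nH]cnc12)C1CC1)C(=O)O` in a functional assay on the whole organism (Tail, strain ICR) with Mus musculus as the target, in the tail flick test, with a stated time of 120 min, at a dose of 25 umol/kg by the oral route; a lower number here means a weaker effect, a higher number a stronger effect of the compound at the dose given: 17%
compound 2 `NC(=O)C[C@H](NC(=O)CN(c1nc(Cl)nc2[nH]cnc12)C1CC1)C(=O)O` in this assay: 17%

Compound 2 stands level with compound 1 at the digits shown, and the one step recorded so far, no change at the digits printed from compound 1 to compound 2 (within the scatter), stayed within the scatter. That step changed a group on a saturated chain carbon, two bonds along the chain from an amide-type nitrogen and a carbonyl carbon, while the shared core of compound 2 was kept.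

Compound 3 `C[C@@H](O)[C@H](NC(=O)CN(c1nc(Cl)nc2[nH]cnc12)C1CC1)C(=O)O` is the next compound. It differs from compound 2 by 1-hydroxyethyl in place of carbamoylmethyl on a saturated chain carbon bound to an amide-type nitrogen and a carbonyl carbon. Among the measured compounds shown here, the only step that bears on it is the one from compound 1 to compound 2, in which exchanging a side-chain group left the read-out unchanged; on that basis one would expect no step beyond the scatter in this assay either, and the step from compound 2 to compound 3 is estimated at no change at the digits printed from compound 2 to compound 3 (within the scatter). For compound 3 the expected value in this assay is 17%, with a range from 5% to 30%.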

Compound 3, a percentage reported as activity, at one dose (the size of the read-out at that dose, not a potency): 37.6%
Compound 3: the middle estimate sits 20.6 percentage points below what was measured; the whole stated range lies below it.
By their numbers in this assay, from the lowest: compounds 1 and 2 (each within the scatter of the next); then compound 3.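

Putting 1-hydroxyethyl in place of carbamoylmethyl gives a number 20.6 percentage points higher from compound 2 to compound 3 (beyond the scatter) in this assay and so shows that the read-out does respond to the group on this saturated chain carbon bound to an amide-type nitrogen and a carbonyl carbon. The larger group of compound 1 gives way to the same 1-hydroxyethyl with a number 20.6 percentage points higher from compound 1 to compound 3 (beyond the scatter) and this places compound 3 clear of both earlier compounds, which the exchange between those two alone could not reveal. Nothing measured here accounts for the rise.

The compounds shown leave open whether the hydroxyl of 1-hydroxyethyl is needed, which a plain ethyl or isopropyl group at this carbon would test. They also leave open how the opposite configuration of the 1-hydroxyethyl group, or a shorter hydroxymethyl chain, would read in this assay here.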